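Replacing nitro with hydroxy in compound 1

A few compounds are considered here, and "the series" means these few. Any claim that something is new, unique, unknown or untested is made for them only; others in the source may bear on it.

Measured in a functional assay on A549 cells (Homo sapiens) for cytotoxicity, read by MTT assay, with a stated time of 6 days; on this read-out lower numbers stand for an effect already at smaller amounts and higher numbers for an effect only at larger amounts of compound:
compound 1 `COC(=O)c1c(-c2ccc([N+](=O)[O-])cc2)oc2ccccc2c1=O`: > 25 ug/mL
compound 2 `COC(=O)c1c(-c2ccc([N+](=O)[O-])cc2)oc2cc(OC)ccc2c1=O`: > 25 ug/mL
compound 3 `COC(=O)c1c(-c2ccc(OCc3ccccc3)cc2)oc2ccc(OC)cc2c1=O`: 22.1 ug/mL

Compound 1 has no number, only a limit of the assay, > 25 ug/mL. Compound 2 likewise gives only a limit, > 25 ug/mL. Little is readable so far, with the data crowded at the limit of > 25 ug/mL in this assay, at which 2 of the 3 values shown sit.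

Compound 4 `COC(=O)c1c(-c2ccc(O)cc2)oc2ccccc2c1=O` keeps the core of compound 1 and changes one group: hydroxy in place of nitro on an aromatic carbon. In short, hydroxy replaces nitro on an aromatic carbon.

Within the data shown here, the one measured step, a step that the two limits leave unreadable from compound 1 to compound 2, is a different change and gives no size to carry over. Only compound 3 reaches a number, 22.1 ug/mL, and it differs from compound 1 in more than one place. Among the measured compounds shown here, with compound 3 at 22.1 ug/mL as the sole guide, no large step is expected in this assay, and any shift should be modest and toward smaller amounts. The expected step is a number no higher from compound 1 to compound 4 (the limit leaves the size open). For compound 4 the estimated value is 25 ug/mL, with an expected range from 11 ug/mL to 55 ug/mL.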

Compound 4, concentration for half-maximal effect: > 25 ug/mL
Compound 4 ended at the assay's limit; the forecaster's own chance of this, stated with the estimate: 55%; the middle value sits exactly at the limit.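

In this assay compound 4 gives only a limit of the assay, > 25 ug/mL. Among these compounds, compound 1 also has only a limit, so no step between compound 1 and compound 4 can be read. As far as these compounds go, whether hydroxy in place of nitro on an aromatic carbon shifts the value at all, and in which direction, stays open.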